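The source may hold more compounds than are shown below. What is called first, only, known or untested is meant among the compounds shown, and "the series" means these compounds.

Among the compounds with values here, in a functional assay on MCF7 cells (Homo sapiens) for antiproliferative activity, read by MTT assay, with a stated time of 48 h (on this read-out lower numbers stand for stronger inhibition and higher numbers for weaker inhibition), compound 2 `CC(C)=CCC[C@]1(C)/C=C/[C@@H](OC(=O)C=C(C)C)[C@](C)(O)/C=C/C(=O)/C(CN2CCN(C)CC2)=C\C1` gives 550 nM, the higher of the two numbers so far, and compound 1 `CC(C)=CCC[C@]1(C)/C=C/[C@@H](OC(=O)C=C(C)C)[C@](C)(O)/C=C/C(=O)/C(CF)=C\C1` gives 240 nM. Compound 3 `CC(C)=CCC[C@]1(C)/C=C/[C@@H](OC(=O)C=C(C)C)[C@](C)(O)/C=C/C(=O)/C(COC(=O)c2ccc([N+](=O)[O-])cc2)=C\C1` carries ((4-nitrophenyl)carbonyl)oxy in place of 4-methylpiperazin-1-yl on a saturated chain carbon bound to a double-bonded ring carbon. Within the data shown here, the only measured step at that carbon is a 2.3-fold higher number from compound 1 to compound 2 (0.36 log units; beyond the scatter). Among the measured compounds shown here, the entering group has no measured precedent, so with this single guide only a modest shift toward a lower number is expected in this assay. The expected step is a 1.6-fold lower number from compound 2 to compound 3 (0.20 log units; within the scatter). Compound 3 is estimated at 350 nM, with a range of 120 nM to 1000 nM.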

Compound 3, half-maximal inhibitory concentration: 670 nM
The estimate for compound 3 lay 1.9-fold (0.28 log units) below the measured number; the range from low to high includes it.
By their numbers in this assay, from the lowest: compound 1; then compounds 2 and 3 (each within the scatter of the next).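

In this assay, ((4-nitrophenyl)carbonyl)oxy in place of 4-methylpiperazin-1-yl on the saturated chain carbon gives a 1.2-fold higher number from compound 2 to compound 3 (0.09 log units; within the scatter) and so leaves the read-out within the scatter, although one group has an aromatic ring of carbon only and the other a non-aromatic ring with two hetero atoms. The same group in place of fluoro gives a 2.8-fold higher number from compound 1 to compound 3 (0.45 log units; beyond the scatter) and thus sets compound 1 apart from both compound 2 and compound 3. No evidence on the cause of these steps is at hand. From the compounds shown here alone, whether a primary amine, a carboxylic acid or a simple hydroxyl at this carbon would read with compound 1 or with compound 2 and compound 3 remains open.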